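The source may report more compounds than this note shows. Statements on the series, on what has been measured and on what is new or still open speak of the compounds shown alone.

Compound 3 `C#Cc1cc(-c2nc3c(F)cccc3s2)ccc1N` is measured in a functional assay on MCF7 cells (Homo sapiens) for inhibition, with a stated time of 72 h (a lower number here means a stronger inhibitor of growth, a higher number a weaker inhibitor of growth), where compound 3 gives 110 nM. Among the three numbers so far it sits second highest. Its nearest neighbour is compound 2 `N#Cc1cc(-c2nc3c(F)cccc3s2)ccc1N`, which in this assay gives 180 nM, the step being a 1.6-fold lower number from compound 2 to compound 3 (0.21 log units; within the scatter). Furthest away is compound 1 `C#Cc1cc(-c2nc3ccccc3s2)ccc1N`, which gives 49 nM, the step being a 2.2-fold higher number from compound 1 to compound 3 (0.35 log units; beyond the scatter).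

Compound 4 `C[Si](C)(C)C#Cc1cc(-c2nc3c(F)cccc3s2)ccc1N` differs from compound 3 by a group of 4 heavy atoms (3 carbon, 1 silicon; no ring) in place of a hydrogen atom, on a triple-bonded carbon. For the measured compounds named here, neither measured step bears directly on this change: one swaps fluoro for hydrogen on an aromatic carbon and is modest, the other swaps ethynyl for cyano and lies within the scatter, and no step so far places any group on the triple-bonded carbon. The expectation for compound 4 in this assay therefore rests on little, and a wide range is the honest answer. Compound 4 is expected to give about 250 nM, with a likely range from 70 nM to 900 nM. That estimate would mean a step of a 2.3-fold higher number from compound 3 to compound 4 (0.36 log units; beyond the scatter).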

Compound 4, concentration for 50% growth inhibition: 520 nM
Estimate against measurement, compound 4: 2.1-fold (0.32 log units) below; the measured number falls inside the stated range.
By their numbers in this assay, from the lowest: compound 1; then compounds 3 and 2 (each within the scatter of the next); then compound 4.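

Until now nothing had been placed on the triple-bonded carbon, and the group of 4 heavy atoms (3 carbon, 1 silicon; no ring) in place of a hydrogen atom there gives, in this assay, a 4.7-fold higher number from compound 3 to compound 4 (0.67 log units; beyond the scatter), so this position responds to the change, and in the direction of weaker growth inhibition. The same group also separates the series from the cyano compound, with a 2.9-fold higher number from compound 2 to compound 4 (0.46 log units; beyond the scatter), whereas the plain ethynyl group and cyano lie within the scatter of each other (a 1.6-fold lower number from compound 2 to compound 3 (0.21 log units; within the scatter)). No measurement here explains why this group raises the number.

With a single group on this carbon, the compounds shown cannot tell whether a smaller methyl or a hydroxymethyl group would stay closer to the plain ethynyl compound. They also leave open whether the same change behaves alike on the core of compound 1, which lacks the fluoro.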